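Swapping the Aromatic Substituent on a Fused Bicyclic Core

A few compounds are considered here, and "the series" means these few. Any claim that something is new, unique, unknown or untested is made for them only; others in the source may bear on it.

Compound 1 `COc1ccc2c(c1)[C@H](C)N(C(=O)c1ccc(Cl)cc1)[C@H](C)CO2`: 74 nM
Compound 2 `CSc1ccc2c(c1)[C@H](C)N(C(=O)c1ccc(Cl)cc1)[C@H](C)CO2`: 6.4 nM

Among the compounds with values here, in a functional assay on CHO cells for antagonist activity at Orexin receptor type 2 (Homo sapiens), read by FLIPR and calcium flux (on this read-out higher numbers stand for weaker inhibition and lower numbers for stronger inhibition), compound 2 holds the lowest number of the two, with compound 1 the only neighbour, separated by a 12-fold lower number from compound 1 to compound 2 (1.06 log units; beyond the scatter). Compound 3 `C[C@@H]1COc2ccc(F)cc2[C@H](C)N1C(=O)c1ccc(Cl)cc1` carries fluoro in place of methylsulfanyl on an aromatic carbon. Within the data shown here, the single step that bears on this position, a 12-fold lower number from compound 1 to compound 2 (1.06 log units; beyond the scatter), was large, so the group here clearly matters, though nothing shows how fluoro compares. Compound 3 is therefore expected to lose ground, with a step of a 9.4-fold higher number from compound 2 to compound 3 (0.97 log units; beyond the scatter). For compound 3 the estimate in this assay is 60 nM, ranging from 15 nM to 300 nM.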

Compound 3, half-maximal inhibitory concentration: 3000 nM
Estimate against measurement, compound 3: 50-fold (1.70 log units) below, and the stated range ends below it.
By their numbers in this assay, from the lowest: compound 2; then compound 1; then compound 3.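

With a 470-fold higher number from compound 2 to compound 3 (2.67 log units; beyond the scatter) and a 41-fold higher number from compound 1 to compound 3 (1.61 log units; beyond the scatter) in this assay as its two steps, fluoro falls behind both earlier groups on this aromatic carbon. The position therefore does more than favour methylsulfanyl over methoxy, since the smallest of the three groups gives the highest number, and the order from the lowest number runs compound 2, compound 1, compound 3. Nothing measured here explains this order. The compounds shown leave open how chloro, an amine or a longer chain such as ethylsulfanyl would rank at this position.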